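Removing the Methyl at the Carbinol Carbon of Compound 3

This account rests on a few compounds, and the source may have more. Where it says the series, first, only, none or still open, it means among the compounds named here.

Going by the values given here, compound 3, with the structure `CC(=O)Nc1cccc(-c2ccc(C(C)(O)c3c[nH]cn3)cc2)c1`, sits second highest among the three numbers so far. In an assay on microsomes from Testis (strain Sprague-Dawley) for inhibition of steroid 17-alpha-hydroxylase/17,20 lyase (Rattus norvegicus) (on this read-out lower numbers stand for stronger inhibition and higher numbers for weaker inhibition), compound 3 gives 62 nM. Its nearest neighbour is compound 2, `CNS(=O)(=O)c1cccc(-c2ccc(C(O)(c3c[nH]cn3)C(C)C)cc2)c1`, which in this assay gives 71 nM, a gap within the scatter. The furthest is compound 1, `CC(=O)Nc1cccc(-c2ccc([C@](O)(c3c[nH]cn3)C(C)C)cc2)c1`, which in this assay gives 14 nM, a gap beyond the scatter.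

Compound 4, `CC(=O)Nc1cccc(-c2ccc(C(O)c3c[nH]cn3)cc2)c1`, has not yet been measured. It differs from compound 3 in one place: hydrogen in place of methyl on a saturated chain carbon bound to two aromatic carbons and an oxygen on a saturated carbon. Among the compounds with values here, no measured pair shows this same change, so no step can be read directly. Compound 1 and compound 3 differ elsewhere as well, so their two values show only that a different substitution at that carbon can move the number beyond the scatter.

For compound 4 the step is expected to be modest and toward a higher number, a 2.4-fold higher number from compound 3 to compound 4 (0.38 log units; beyond the scatter). In this assay compound 4 is therefore estimated at 150 nM, between 50 nM and 500 nM.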

Compound 4, half-maximal inhibitory concentration: 320 nM
Compound 4: middle estimate off by 2.1-fold (0.33 log units), on the low side, within the range that was stated.
By their numbers in this assay, from the lowest: compound 1; then compounds 3 and 2 (each within the scatter of the next); then compound 4.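

Going by these compounds alone, the pair gives the first direct reading of this change: in this assay, hydrogen in place of methyl on a saturated chain carbon bound to two aromatic carbons and an oxygen on a saturated carbon brings a 5.2-fold higher number from compound 3 to compound 4 (0.71 log units; beyond the scatter) and so moves the number up beyond the scatter. A single carbon is therefore enough to separate two otherwise identical compounds at this position, and the step comes with no hydrogen-bond donor or acceptor counted in the group that leaves. Nothing measured here accounts for the size of this step.

The compounds shown leave open how an ethyl group or a longer unbranched chain would read at this same carbon. They also leave open whether the methyl step would keep its size with a carboxylic acid in place of the acetamide end of the molecule.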